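The source may report more compounds than this note shows. Statements on the series, on what has been measured and on what is new or still open speak of the compounds shown alone.

Compound 3 `Cc1ccc(CNC(=O)c2cccc(C(C)Oc3ccnc(Nc4cnn(C)c4)c3)c2)cc1` stands lowest of the three compounds measured in a functional assay on NCI-H3122 cells (Homo sapiens) for antiproliferative activity, read by MTT assay, with a stated time of 48 h (a lower number here means a stronger inhibitor, a higher number a weaker inhibitor), where compound 3 gives 7700 nM. Compound 1 `COc1ccc(CNC(=O)c2cccc(C(C)Oc3ccnc(Nc4cnn(C)c4)c3)c2)cc1OC` gives 38500 nM in this assay, and compound 2 `CC(Oc1ccnc(Nc2cnn(C)c2)c1)c1cccc(C(=O)NCc2ccc(C#N)cc2)c1` gives 35100 nM. The step of a 5.0-fold lower number from compound 1 to compound 3 (0.70 log units; beyond the scatter) and the step of a 4.6-fold lower number from compound 2 to compound 3 (0.66 log units; beyond the scatter) both lie beyond the scatter, while the step of a 1.1-fold lower number from compound 1 to compound 2 (0.04 log units; within the scatter) does not.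

Compound 4 `Cc1ccc(CNC(=O)c2cccc(C(C)Oc3ccnc(NN4CCOCC4)c3)c2)cc1` differs from compound 3 at the other end of the shared core: morpholin-4-yl in place of 1-methyl-1H-pyrazol-4-yl on a nitrogen on an aromatic ring. Going by the values given here, none of the measured steps touches this place; all three concern the group on the saturated chain carbon bound to the amide-type nitrogen. Among the compounds with values here, the data therefore give no step of comparable kind, and what the change will do in this assay cannot be read from the measured compounds.

For compound 4 a number somewhat higher than that of compound 3 is expected, the step of a 1.9-fold higher number from compound 3 to compound 4 (0.29 log units; within the scatter) being an estimate with little support. Compound 4 is estimated at 15000 nM, within a range from 4000 nM to 60000 nM.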

Compound 4, half-maximal inhibitory concentration: > 100000 nM
Compound 4: no number, only a limit; the forecaster's own chance of this, stated with the estimate: 15%; middle value at least 6.6-fold (0.82 log units) from the limit.
By their numbers in this assay, from the lowest: compound 3; then compounds 2 and 1 (each within the scatter of the next). At a limit, above all of these: compound 4.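

Until now every step concerned the group on the saturated chain carbon bound to the amide-type nitrogen; the change on a nitrogen on an aromatic ring, from 1-methyl-1H-pyrazol-4-yl to morpholin-4-yl, gives an at least 12-fold higher number from compound 3 to compound 4 (1.11 log units; beyond the scatter) in this assay. Going by these compounds alone, this step is large, whereas the earlier steps were modest or within the scatter, so two groups with the same heavy-atom and acceptor counts are far from interchangeable at this place. For compound 4 the result is a limit of the assay and not a number: the limit of > 100000 nM in this assay, at which 1 of the 4 values shown sits.

This one step swaps a five-membered aromatic ring for a six-membered non-aromatic ring and also changes the hetero atoms, and the compounds shown do not separate these differences. Going by these compounds, how a phenyl ring or a piperidin-1-yl group would read at this place remains open.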